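The source may report more compounds than this note shows. Statements on the series, on what has been measured and on what is new or still open speak of the compounds shown alone.

Measured compounds:
compound 1 `Fc1cccc(-c2nc(Nc3ccccc3)c3ccccc3n2)c1` – in a functional assay on MDA-MB-231 cells (Homo sapiens) for cytotoxicity, read by MTT assay, with a stated time of 48 h (on this read-out higher numbers stand for weaker inhibition and lower numbers for stronger inhibition), compound 1 gives > 50000 nM, a limit of the assay, not a number.
compound 2 `Fc1ccc2nc(-c3ccccc3)nc(Nc3ccccc3)c2c1` – in this assay compound 2 gives > 50000 nM, likewise a limit of the assay.

Compound 2 therefore stands at the limit of > 50000 nM in this assay, at which 2 of the 2 values shown sit, so no order between compound 1 and compound 2 can be read. Compound 3 `Fc1cccc(-c2nc(Nc3ccccc3)c3cc(F)ccc3n2)c1` is not yet measured. From compound 2 to compound 3 the change is fluoro in place of hydrogen on an aromatic carbon. With both known values sitting at the limit, no step beyond the scatter is expected in this assay in either direction. Compound 3 is therefore expected to give 60000 nM (range 20000 nM to 200000 nM), most likely again only a limit, with the expected step from compound 2 to compound 3 being a step that the limit leaves unreadable from compound 2 to compound 3.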

Compound 3, half-maximal inhibitory concentration: 47800 nM
Beside the measured number, compound 3's estimate is 1.3-fold (0.10 log units) above it; measured number inside the range.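

In this assay, compound 3, which carries fluoro at both places, is the first compound shown with a number rather than a limit, yet the readable change is only an at least 1.0-fold lower number from compound 2 to compound 3 (0.01 log units; that floor lies within the scatter), and on the other side an at least 1.0-fold lower number from compound 1 to compound 3 (0.01 log units; that floor lies within the scatter). Neither step separates fluoro from hydrogen at either place. Compound 1 and compound 2 remain limits of the assay: the limit of > 50000 nM in this assay, at which 2 of the 3 values shown sit.

How far compound 1 and compound 2 actually lie from compound 3 cannot be read. Also open, going by these compounds, is whether an amine or a carboxylic acid in place of fluoro would give a step beyond the scatter.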